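The compounds below may be only part of what the source reports. "The series", "measured", "known", "first", "only" and "open" are said of these compounds alone.

Series in a functional assay on IMR-32 cells with melanin-concentrating hormone receptor 1 (Homo sapiens) as the target, read by fluorescence; on this read-out higher numbers stand for weaker inhibition and lower numbers for stronger inhibition:
compound 1 `CC(CNC1CC1)Oc1cccc2ccc(N)nc12`, 580 nM
compound 2 `CC(CN1CCCC1)Oc1cccc2ccc(N)nc12`, 360 nM
compound 3 `CC(CNCc1ccccc1)Oc1cccc2ccc(N)nc12`, 340 nM

Compound 3 has the lowest of the three numbers, but its gaps to compound 2 and to compound 1 lie within the scatter, so the three compounds are not separated on this read-out. The next compound is compound 4 `CC(CNCc1ccsc1)Oc1cccc2ccc(N)nc12`, which differs from compound 3 by thiophen-3-yl in place of phenyl on a saturated chain carbon bound to an amine nitrogen. Among the compounds with values here, no measured step exchanges one aromatic ring for another. Within the data shown here, the only step that touches the benzyl group is a 1.7-fold lower number from compound 1 to compound 3 (0.23 log units; within the scatter), within the scatter, and a 1.6-fold lower number from compound 1 to compound 2 (0.21 log units; within the scatter) is within the scatter as well; nothing measured so far moves this read-out beyond the scatter. Compound 4 is therefore expected to change little, the expected step being a 1.0-fold higher number from compound 3 to compound 4 (0.01 log units; within the scatter). Compound 4 is estimated at 350 nM, within 150 nM to 800 nM.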

Compound 4, half-maximal inhibitory concentration: 150 nM
Compound 4: middle estimate off by 2.3-fold (0.37 log units), on the high side; low and high end bracket the measured number.
By their numbers in this assay, from the lowest: compound 4; then compounds 3, 2 and 1 (each within the scatter of the next).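

In this assay, within the data shown here, thiophen-3-yl in place of phenyl on a saturated chain carbon bound to an amine nitrogen is the first change to move the number beyond the scatter (a 2.3-fold lower number from compound 3 to compound 4 (0.36 log units; beyond the scatter)). Compound 4 also separates from the two other comparators (a 2.4-fold lower number from compound 2 to compound 4 (0.38 log units; beyond the scatter); a 3.9-fold lower number from compound 1 to compound 4 (0.59 log units; beyond the scatter)), whereas compounds 1, 2 and 3 are not separated from one another. No evidence is available to explain the gain from this ring exchange.

Open, going by these compounds, is whether thiophen-2-yl or furan-3-yl would keep the step. Also open, on these data alone, is whether a pyridin-3-yl ring would do the same.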